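Compound 3: fluoro in place of methoxy

The compounds below may be only part of what the source reports. "The series", "measured", "known", "first", "only" and "open" are said of these compounds alone.

In a functional assay on A549 cells (Homo sapiens) for antiproliferative activity, read by MTT assay, with a stated time of 72 h (a lower number here means a stronger inhibitor, a higher number a weaker inhibitor), compound 1 (`COc1cc2ncnc(Nc3ccc(Br)cc3F)c2cc1OCCCN1CCNCCNCC1`) gives 16100 nM as a measured value. Compound 2 (`COc1cccc(Nc2ncnc3cc(OC)c(OCCCN4CCNCCNCC4)cc23)c1`) sits at > 50000 nM as a limit of the assay, not a number. Going by the values given here, the one measured step is an at least 3.1-fold higher number from compound 1 to compound 2 (0.49 log units; beyond the scatter) with 3-methoxyphenyl in place of 4-bromo-2-fluorophenyl, beyond the scatter. Compound 3 (`COc1cc2ncnc(Nc3cccc(F)c3)c2cc1OCCCN1CCNCCNCC1`) differs from compound 2 by fluoro in place of methoxy on an aromatic carbon with fluoro in place of methoxy on an aromatic carbon, meta to a large group. Compound 1 at 16100 nM also bears fluoro, so a move to a lower number is expected, partly retracing that step. The expected change is an at least 1.7-fold lower number from compound 2 to compound 3 (0.25 log units; that floor lies within the scatter) in this assay and a reading at the limit stays possible. Compound 3 is estimated at 28000 nM within 11000 nM to 60000 nM as a working figure.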

Compound 3, half-maximal inhibitory concentration: > 50000 nM
Compound 3 was reported as a limit (the forecaster's own chance of this, stated with the estimate: 35%); at least 1.7-fold (0.25 log units) between middle value and limit.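

In this assay compound 3 gives > 50000 nM as a limit of the assay, not a number. Fluoro on the ring does not by itself keep a measurable reading: 3-fluorophenyl in place of 4-bromo-2-fluorophenyl gives an at least 3.1-fold higher number from compound 1 to compound 3 (0.49 log units; beyond the scatter), the same floor seen with 3-methoxyphenyl. The step from methoxy to fluoro cannot be read, because both compounds sit at one limit: the limit of > 50000 nM in this assay, at which 2 of the 3 values shown sit.

Still open, as far as these compounds go, is whether 4-bromophenyl, 3-chlorophenyl or 3-aminophenyl on this nitrogen gives a measurable number. Which part of 4-bromo-2-fluorophenyl carries the lower reading also stays unresolved.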